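Dithiocarbamate series: cytotoxicity notes before the next measurement

A few compounds are considered here, and "the series" means these few. Any claim that something is new, unique, unknown or untested is made for them only; others in the source may bear on it.

Measured compounds and values:
compound 1 `Cc1c(CNC(=S)SCCC#N)cnn1-c1ccccc1`: 24900 nM
compound 2 `S=C(NCc1cccnc1)SCCc1nc2ccccc2[nH]1`: 9300 nM
compound 3 `S=C(NCc1cccnc1)SCCc1nnc(-c2ccc(Cl)cc2)o1`: 1260 nM

All three were run in a functional assay on Bel-7402 cells (Homo sapiens) for cytotoxicity, read by resazurin assay, with a stated time of 72 h; on this read-out higher numbers stand for weaker inhibition and lower numbers for stronger inhibition. Compound 3 gives the lowest number of the three in this assay. Compound 2 stands nearest to it, and that gap is beyond the scatter; compound 1 stands furthest, also beyond the scatter. Going by the values given here, no two measured compounds differ in only one place, so none of these gaps can be tied to a single structural change, and nothing is known about what any one change does in this assay.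

The next compound is compound 4 `S=C(NCc1cccnc1)SCCc1nnc(-c2cc3ccccc3s2)o1`. It keeps the whole of compound 3 except for one group: 1-benzothiophen-2-yl in place of 4-chlorophenyl on an aromatic carbon.

Among the compounds with values here, no measured pair shows a change of this kind, so there is no basis for expecting a large step in either direction. The expected step of a 1.3-fold lower number from compound 3 to compound 4 (0.10 log units; within the scatter) is therefore set small, within the scatter, with a wide range to cover the lack of precedent. For compound 4 the value in this assay is estimated at 1000 nM, with a range from 300 nM to 3500 nM.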

Compound 4, half-maximal inhibitory concentration: 6890 nM
Estimate against measurement, compound 4: 6.9-fold (0.84 log units) below; measured number above the stated range.
By their numbers in this assay, from the lowest: compound 3; then compounds 4 and 2 (each within the scatter of the next); then compound 1.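

Going by these compounds alone, this is the first step that can be read at a single place: in this assay, 1-benzothiophen-2-yl in place of 4-chlorophenyl on an aromatic carbon of the five-membered aromatic ring with 2 nitrogen and 1 oxygen gives a 5.5-fold higher number from compound 3 to compound 4 (0.74 log units; beyond the scatter). The position is therefore not indifferent to the group it carries, and here the two-ring group with its ring sulfur stands on the weaker side of the 4-chlorophenyl group, with the rest of the structure unchanged. Within the data shown here, the single step gives the size and direction of this exchange, and no measurement at hand accounts for it.

The exchange alters ring count, ring type and the chlorine together, so the compounds shown do not separate the contribution of each, and it remains open whether a plain phenyl, a thiophen-2-yl or a naphthalen-2-yl at this place would lie nearer compound 3 or compound 4. As far as these compounds go, it is also open whether the step would keep its size and direction with the pyridin-3-ylmethyl group on the nitrogen replaced by a different group, such as a benzyl.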